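Dichloro to dimethoxy on the benzylic arm of a shared core

The source may report more compounds than this note shows. Statements on the series, on what has been measured and on what is new or still open speak of the compounds shown alone.

Compound 1 `CCOC(=O)[C@H](CCC(=O)O)NC(=O)c1ccc(CNc2nc3cc(N)cc(N)c3nc2-c2ccccc2)cc1` and compound 2 `Nc1cc(N)c2nc(-c3ccccc3)c(NCc3ccc(Cl)c(Cl)c3)nc2c1` share the same core and are both tested in a functional assay on SK-MEL-28 cells (Homo sapiens) for inhibition, read by sulforhodamine B assay, with a stated time of 48 h; on this read-out lower numbers stand for stronger inhibition of growth and higher numbers for weaker inhibition of growth. In this assay compound 1 gives 56200 nM, and compound 2 gives 41700 nM; the two numbers stand within the usual scatter of each other, so compound 2 is not set apart from compound 1. Compound 3 `COc1ccc(CNc2nc3cc(N)cc(N)c3nc2-c2ccccc2)cc1OC` differs from compound 2 by 3,4-dimethoxyphenyl in place of 3,4-dichlorophenyl on a saturated chain carbon bound to a nitrogen on an aromatic ring. Among the compounds with values here, no measured pair shows this change, so for compound 3 the expected step is a 1.2-fold higher number from compound 2 to compound 3 (0.08 log units; within the scatter), none beyond the scatter in either direction. Compound 3 is estimated at 50000 nM, within 20000 nM to 130000 nM.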

Compound 3, concentration for total growth inhibition: 30200 nM
Beside the measured number, compound 3's estimate is 1.7-fold (0.22 log units) above it, within the range that was stated.
By their numbers in this assay, from the lowest: compounds 3, 2 and 1 (each within the scatter of the next).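

In this assay, 3,4-dimethoxyphenyl in place of 3,4-dichlorophenyl on this saturated chain carbon gives a 1.4-fold lower number from compound 2 to compound 3 (0.14 log units; within the scatter), so replacing both chlorine atoms with oxygen-linked groups does not separate the two compounds. This position therefore accepts a group with 2 hydrogen-bond acceptors in place of one with 0, with no step beyond the scatter. Nothing measured here offers an explanation for this result.

Going by these compounds, it remains open whether a phenyl group carrying an amine or a carboxylic acid at this position would give a step beyond the scatter. The effect of a longer chain between the nitrogen and the ring is also unresolved.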